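The source may hold more compounds than are shown below. What is called first, only, known or untested is meant among the compounds shown, and "the series" means these compounds.

Three measured compounds, all sharing one core:

Compound 1 `CNC(=O)N1CCCc2ccc(NC(=O)c3ccc(-c4ccccc4)cc3)cc21` gives 19.7% in a functional assay on MV4-11 cells (Homo sapiens) for antiproliferative activity, with a stated time of 6 days, tested at 1.56 uM; a higher number here means a stronger effect of the compound at the concentration tested, a lower number a weaker effect.
Compound 2 `CNC(=O)N1CCCc2ccc(NC(=O)c3cccc(-c4cn[nH]c4)c3)cc21` gives 27.9% in this assay.
Compound 3 `CNC(=O)N1CCCc2ccc(NC(=O)c3cccc(-c4ccn(S(C)(=O)=O)n4)c3)cc21` gives 4.03% in this assay.

Compound 1 stands second highest of these three numbers. Its nearest neighbour is compound 2, whose value lies within the scatter of that of compound 1, so the two cannot be ordered. Compound 3 lies furthest away, beyond the scatter.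

Compound 4 `CNC(=O)N1CCCc2ccc(NC(=O)c3ccc(-c4ccn(C(C)=O)n4)cc3)cc21` is not yet measured. It differs from compound 1 in one place: 1-acetyl-1H-pyrazol-3-yl in place of phenyl on an aromatic carbon.

Going by the values given here, no measured step changes a phenyl in this way. The nearest comparison is the step of a number 23.9 percentage points lower from compound 2 to compound 3 (beyond the scatter), where an unsubstituted pyrazolyl became a pyrazol-3-yl carrying a group on its nitrogen, and the read-out fell to the lowest of the three values. Compound 4 also carries a pyrazol-3-yl with a group on its nitrogen, here an acetyl. A drop beyond the scatter is therefore expected, of roughly a number 11.7 percentage points lower from compound 1 to compound 4 (beyond the scatter), landing compound 4 near compound 3. Compound 4 is estimated to give 8% in this assay, with a range from 0% to 20%.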

Compound 4, a percentage reported as inhibition, at one concentration (the size of the read-out at that concentration, not a potency): 35.8%
Beside the measured number, compound 4's estimate is 27.8 percentage points below it, outside the stated range (above it).
By their numbers in this assay, from the lowest: compound 3; then compounds 1, 2 and 4 (each within the scatter of the next, the first and the last beyond it).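

At this position, para to a large group, the phenyl of compound 1 is not required for the read-out in this assay: the change to 1-acetyl-1H-pyrazol-3-yl gives a number 16.1 percentage points higher from compound 1 to compound 4 (beyond the scatter). The earlier step, a number 23.9 percentage points lower from compound 2 to compound 3 (beyond the scatter), also ended in a pyrazol-3-yl with a group on its nitrogen, yet it went the other way, so such a ring does not lower the read-out in every setting. Nothing available here explains why the read-out rises with this change.

The compounds shown cannot separate the part played by the pyrazole ring from that of its acetyl group at this position. Also open, as far as these compounds go, is how a 1-methyl-1H-pyrazol-3-yl, with a methyl in place of the acetyl, or a pyridyl ring would read at the same place.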